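The source may hold more compounds than are shown below. What is called first, only, known or untested is meant among the compounds shown, and "the series" means these compounds.

Measured compounds:
- compound 1 `Cc1cccc(/C(N)=N/NC(=S)N2CCN(c3ccccn3)CC2)n1`: 43%
- compound 2 `N/C(=N\NC(=S)N1CCCC1)c1ccc(F)cn1`: 78.7%
- compound 3 `Cc1cccc(/C(N)=N/NC(=S)N2CCSCC2)n1`: 53.2%

In a functional assay on A-431 cells (Homo sapiens) for cytotoxicity, read by MTT assay, with a stated time of 72 h, tested at 10 uM (a higher number here means more inhibition of growth at the concentration tested, a lower number less inhibition of growth), compound 1 gives the lowest of the three numbers. Compound 3 sits closest to it, with a number somewhat higher, beyond the scatter, and compound 2 lies furthest, with a much higher number. Compound 4 `Cc1ccnc(/C(N)=N/NC(=S)N2CCN(c3ccccn3)CC2)c1` has not yet been measured in this assay. It differs from compound 1 only in where the methyl sits on the pyridine: 4-methylpyridin-2-yl in place of 6-methylpyridin-2-yl on a carbon with a double bond to nitrogen. Going by the values given here, no measured pair shows the effect of such a move, so the step is expected to be small, in either direction, and likely within the scatter. Compound 4 is therefore estimated to give 46%, ranging from 26% to 66%, an expected shift of a number 3 percentage points higher from compound 1 to compound 4 (within the scatter).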

Compound 4, percent growth inhibition at one concentration: 44%
Beside the measured number, compound 4's estimate is 2 percentage points above it, within the range that was stated.
By their numbers in this assay, from the lowest: compounds 1, 4 and 3 (each within the scatter of the next, the first and the last beyond it); then compound 2.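

In this assay moving the methyl gives a number 1 percentage points higher from compound 1 to compound 4 (within the scatter) and so 4-methylpyridin-2-yl and 6-methylpyridin-2-yl cannot be told apart at this place. Going by these compounds alone, this is the first measured step at this position, and it shows that, with the rest of compound 1 kept, this shift of the methyl leaves the growth inhibition within the scatter. No available evidence offers an explanation for this result.

Still open, on these data alone, is what happens when the methyl is replaced by a different group, such as an amine or a methoxy group. Within the data shown here, it is also unknown whether the same shift gives a similar result when the other end of the molecule is the one in compound 3.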